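Aryl glucoside series: solubility read-across to the acetyl analogue

The source may hold more compounds than are shown below. What is called first, only, known or untested is meant among the compounds shown, and "the series" means these compounds.

Measured so far:
- compound 1, `Cc1cccc(-c2ccc(O[C@H]3O[C@H](CO)[C@@H](O)[C@H](O)[C@@H]3O)c(Cl)c2)c1`: 7.1 ug/mL
- compound 2, `N#Cc1ccc(-c2ccc(O[C@H]3O[C@H](CO)[C@@H](O)[C@H](O)[C@@H]3O)c(Cl)c2)cc1`: 192 ug/mL

In a physicochemical assay for solubility, measured as kinetic solubility, with a stated time of 15 h, at pH 7.4 (on this read-out higher numbers stand for higher solubility and lower numbers for lower solubility), compound 1 gives 7.1 ug/mL, the lowest of the two numbers shown; compound 2 gives 192 ug/mL. Among the measured compounds shown here, the only step between measured compounds is a 27-fold higher number from compound 1 to compound 2 (1.43 log units; beyond the scatter), which is large and beyond the scatter.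

Compound 3 is `CC(=O)c1ccc(-c2ccc(O[C@H]3O[C@H](CO)[C@@H](O)[C@H](O)[C@@H]3O)c(Cl)c2)cc1`, not yet measured in this assay. Its difference from compound 1 is 4-acetylphenyl in place of 3-methylphenyl on an aromatic carbon. The step from compound 1 to compound 2 bears on it directly, since there too the 3-methylphenyl is replaced by a 4-substituted phenyl on the same aromatic carbon, and that step was a 27-fold higher number from compound 1 to compound 2 (1.43 log units; beyond the scatter). A rise beyond the scatter is therefore expected for compound 3, though the step is estimated to be somewhat smaller than with 4-cyanophenyl, as an 8.5-fold higher number from compound 1 to compound 3 (0.93 log units; beyond the scatter). Compound 3 is estimated at 60 ug/mL, with a range of 20 ug/mL to 180 ug/mL.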

Compound 3, solubility: 16 ug/mL
Beside the measured number, compound 3's estimate is 3.8-fold (0.57 log units) above it; the whole stated range lies above it.
By their numbers in this assay, from the lowest: compound 1; then compound 3; then compound 2.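

In this assay, replacing 3-methylphenyl with 4-acetylphenyl gives only a 2.3-fold higher number from compound 1 to compound 3 (0.35 log units; beyond the scatter), so the large gain seen with 4-cyanophenyl does not carry over in full to this closely related replacement. Acetyl in place of cyano gives a 12-fold lower number from compound 2 to compound 3 (1.08 log units; beyond the scatter), which shows that the read-out at this position depends on the identity of the group on the phenyl ring and not only on the loss of 3-methylphenyl. No measurement at hand accounts for the gap between the cyano and acetyl compounds.

From the compounds shown here alone, it remains open how an amine or a carboxylic acid in place of cyano would rank against compound 2. The change of group and the change of its place on the phenyl ring also remain unseparated: compound 1 differs from compound 2 and compound 3 in both.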